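Quinolinyl to ethoxyhydroxyphenyl on an adenosine hydrazone

The source may report more compounds than this note shows. Statements on the series, on what has been measured and on what is new or still open speak of the compounds shown alone.

For the measured compounds named here, compound 1 `Nc1nc(N/N=C/c2ccc3ncccc3c2)nc2c1ncn2[C@@H]1O[C@H](CO)[C@@H](O)[C@H]1O` is the only compound in this set with a measured number in an assay on CHO-K1 cells for displacement of a labelled ligand from adenosine receptor A1 (Homo sapiens), read by scintillation counting, with a stated time of 60 min; a higher number here means a weaker inhibitor, a lower number a stronger inhibitor: here compound 1 gives 9.8 nM. Compound 2 `COc1cc(/C=N/Nc2nc(N)c3ncn([C@@H]4O[C@H](CO)[C@@H](O)[C@H]4O)c3n2)cc(OC)c1OC` reaches only a limit of this assay, > 10000 nM. Compound 1 therefore stands as the single number shown, the other value sitting at the limit (the limit of > 10000 nM in this assay, at which 1 of the 2 values shown sits). Compound 3 `CCOc1cc(/C=N/Nc2nc(N)c3ncn([C@@H]4O[C@H](CO)[C@@H](O)[C@H]4O)c3n2)ccc1O` has not yet been measured in this assay. It differs from compound 1 by 3-ethoxy-4-hydroxyphenyl in place of quinolin-6-yl on a carbon with a double bond to nitrogen. Going by the values given here, no measured step between neighbouring compounds is available, so the size of this step cannot be read from the data. Compound 2 also carries a substituted phenyl in this position and gives no number. A large loss is therefore expected for compound 3, a 200-fold higher number from compound 1 to compound 3 (2.31 log units; beyond the scatter), and its inhibition constant is estimated at 2000 nM, with a range from 300 nM to 10000 nM.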

Compound 3, inhibition constant: 6940 nM
For compound 3 the middle estimate is 3.5-fold (0.54 log units) below the measured one; low and high end bracket the measured number.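

In this assay, 3-ethoxy-4-hydroxyphenyl in place of quinolin-6-yl on a carbon with a double bond to nitrogen gives a 710-fold higher number from compound 1 to compound 3 (2.85 log units; beyond the scatter), so this position now has a measured step, and it is a large one. Compound 3 still gives a number, 6940 nM, which shows that a substituted phenyl here can stay within the measurable range of this assay. Compound 2, which also carries a substituted phenyl here, gives only a limit, so no step to it can be read: the limit of > 10000 nM in this assay, at which 1 of the 3 values shown sits.

The compounds shown do not separate the loss of the quinolin-6-yl group from the entry of the ethoxy and hydroxy groups. An unsubstituted phenyl, a naphthyl or an isoquinolinyl group on the same carbon would begin to tell these apart.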